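The source may hold more compounds than are shown below. What is called first, only, known or untested is meant among the compounds shown, and "the series" means these compounds.

Measured so far:
compound 1 `COc1ccc(-c2cn3ccnc3c(-c3ccc4ncn(C5CCCCC5)c4c3)n2)cc1`: -8.48%
compound 2 `Fc1ccc(-c2cn3ccnc3c(-c3ccc4ncn(C5CCCCC5)c4c3)n2)cc1`: 24.4%

In a functional assay on RXF 393 cells (Homo sapiens) for inhibition, read by sulforhodamine B assay, with a stated time of 48 h, tested at 10 uM (on this read-out lower numbers stand for less inhibition and higher numbers for more inhibition at the one concentration tested (going by the name of the read-out)), compound 2 stands highest of the two numbers, and its nearest neighbour is compound 1, whose value is lower by a number 32.9 percentage points higher from compound 1 to compound 2 (beyond the scatter). Compound 3 `Clc1ccc(-c2cn3ccnc3c(-c3ccc4ncn(C5CCCCC5)c4c3)n2)cc1` differs from compound 2 by chloro in place of fluoro on an aromatic carbon. No measured step swaps fluoro for chloro; the only step shown concerns methoxy against fluoro, so it bears on this change only loosely. Compound 3 is therefore expected to stay close to compound 2, with a step of a number 5.6 percentage points higher from compound 2 to compound 3 (within the scatter). The estimate for compound 3 in this assay is 30%, within 10% to 50%.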

Compound 3, a percentage reported as inhibition, at one concentration (the size of the read-out at that concentration, not a potency): 6.73%
Estimate against measurement, compound 3: 23.3 percentage points above; measured number below the stated range.
By their numbers in this assay, from the lowest: compound 1; then compound 3; then compound 2.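

At this place, para to a large group on a six-membered aromatic ring of carbon only, the choice between two halogens matters in this assay: 4-fluorophenyl to 4-chlorophenyl gives a number 17.7 percentage points lower from compound 2 to compound 3 (beyond the scatter). Chloro still stands above methoxy, with a number 15.2 percentage points higher from compound 1 to compound 3 (beyond the scatter), so chloro falls between the other two groups rather than matching fluoro. Nothing available here explains this order. From the compounds shown here alone, whether bromo, trifluoromethyl or a dimethylamino group would fit this order remains open. So does whether a carboxylic acid at this place would exceed fluoro.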